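Diaryl ureas on HCC827 cells: a bromo-methoxyphenyl variant

This account rests on a few compounds, and the source may have more. Where it says the series, first, only, none or still open, it means among the compounds named here.

compound 1 `COc1ccc(F)cc1Nc1cc(NC(=O)Nc2c(Cl)cccc2Cl)ncn1` — 78%
compound 2 `Cc1ccc(Nc2cc(NC(=O)Nc3c(Cl)cccc3Cl)ncn2)cc1C` — 84.3%
compound 3 `COc1cc(NC(=O)Nc2cc(Nc3cccc(C(C)(C)C)c3)ncn2)cc(OC)c1` — 48.7%

In a functional assay on HCC827 cells (Homo sapiens) for inhibition, read by MTT assay, with a stated time of 48 h, tested at 10 uM (a higher number here means more inhibition at the concentration tested (going by the name of the read-out), a lower number less inhibition), compound 2 gives the highest of the three numbers, with compound 1 nearest and compound 3 furthest. Compound 4 `COc1cc(Br)ccc1Nc1cc(NC(=O)Nc2c(Cl)cccc2Cl)ncn1` differs from compound 2 in one place: 4-bromo-2-methoxyphenyl in place of 3,4-dimethylphenyl on a nitrogen on an aromatic ring. For the measured compounds named here, only one measured step touches this same position, the one a number 6.3 percentage points higher from compound 1 to compound 2 (within the scatter), and it stayed within the scatter. Compound 3 differs from compound 2 at more than one place, so its lower value is merely noted. Compound 4, like compound 1, carries a methoxy group on this ring, and compound 1 gives 78%. Compound 4 is therefore expected to give about 79%, between 64% and 91%. The step of a number 5.3 percentage points lower from compound 2 to compound 4 (within the scatter) is expected to remain within the scatter.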

Compound 4, a percentage reported as inhibition, at one concentration (the size of the read-out at that concentration, not a potency): 42.7%
The estimate for compound 4 lay 36.3 percentage points above the measured number, outside the stated range (below it).
By their numbers in this assay, from the lowest: compounds 4 and 3 (each within the scatter of the next); then compounds 1 and 2 (each within the scatter of the next).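

In this assay this position proves far less forgiving than the first step suggested, with the 4-bromo-2-methoxyphenyl group giving a number 41.6 percentage points lower from compound 2 to compound 4 (beyond the scatter). A methoxy group alone does not keep the number high, since compound 1 and compound 4 both carry one on this ring and still show a number 35.3 percentage points lower from compound 1 to compound 4 (beyond the scatter). No measurement available here explains this drop.

On these data alone, it remains open whether the bromine or its combination with the methoxy group goes with the lower number. A plain 4-bromophenyl group, or an amine on this ring, would help separate these possibilities.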